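Notes on a methoxy step carried to a second core

The compounds below may be only part of what the source reports. "The series", "measured", "known", "first", "only" and "open" are said of these compounds alone.

Compound 1 `COc1ccc(-c2cc(C(=O)Nc3nc4ccc(F)cc4s3)nc3cc(-c4ccccc4)nn23)cc1` and compound 2 `COc1ccc(-c2cc(C(=O)Nc3nc4ccc(F)cc4s3)nc3cc(-c4ccccc4)nn23)cc1OC` share one core, while compound 3 `COc1ccc(-c2cc(C(=O)Nc3nc4ccccc4s3)nc3cc(-c4ccccc4)nn23)cc1` and compound 4 `COc1ccc(-c2cc(C(=O)Nc3nc4ccccc4s3)nc3cc(-c4ccccc4)nn23)cc1OC` share another. In a functional assay on DU-145 cells (Homo sapiens) for cytotoxicity, read by MTT assay, with a stated time of 48 h (a lower number here means a stronger inhibitor, a higher number a weaker inhibitor), compound 1 gives 31400 nM, compound 2 gives 18600 nM and compound 3 gives 2950 nM. The change methoxy in place of hydrogen on an aromatic carbon yields a 1.7-fold lower number from compound 1 to compound 2 (0.23 log units; within the scatter). The two cores differ by hydrogen in place of fluoro on an aromatic carbon, and that change yields an 11-fold lower number from compound 1 to compound 3 (1.03 log units; beyond the scatter). The same change is now made on the core of compound 3 as methoxy in place of hydrogen on an aromatic carbon, at a place that reads the same word for word as before, so it is taken as the same change. Compound 4 has not yet been measured in this assay. A step of a 1.6-fold lower number from compound 3 to compound 4 (0.21 log units; within the scatter) is expected, resting on the single earlier pass a 1.7-fold lower number from compound 1 to compound 2 (0.23 log units; within the scatter). Compound 4 is estimated at 1800 nM, with a range from 600 nM to 5500 nM.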

Compound 4, half-maximal inhibitory concentration: 19100 nM
For compound 4 the middle estimate is 11-fold (1.03 log units) below the measured one; the measured number lies above the stated range.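

In this assay, the methoxy change does not carry over from one core to the other, since a 6.5-fold higher number from compound 3 to compound 4 (0.81 log units; beyond the scatter) stands against the earlier step: the same change on two cores in this assay, a 1.7-fold lower number (0.23 log units; within the scatter) from compound 1 to compound 2 and a 6.5-fold higher number (0.81 log units; beyond the scatter) from compound 3 to compound 4, 11-fold (1.04 log units) apart, beyond the scatter of two such steps.
Hydrogen in place of fluoro is equally tied to its setting, with a 1.0-fold higher number from compound 2 to compound 4 (0.01 log units; within the scatter) set against the large earlier step: the same change on two cores in this assay, an 11-fold lower number (1.03 log units; beyond the scatter) from compound 1 to compound 3 and a 1.0-fold higher number (0.01 log units; within the scatter) from compound 2 to compound 4, 11-fold (1.04 log units) apart, beyond the scatter of two such steps.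
The four compounds show that these two changes do not add up across this pair of cores, but they give no cause and say nothing about any other core.

From the compounds shown here alone, it remains open whether an amine or a carboxylic acid, on the aromatic carbon ortho to a methoxy group, would depend on the core in the same way. Going by these compounds, whether chloro in place of fluoro would behave like fluoro also remains open.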